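A Hydroxy-for-Chloro Swap on a Receptor-Binding Scaffold

A few compounds are considered here, and "the series" means these few. Any claim that something is new, unique, unknown or untested is made for them only; others in the source may bear on it.

Three compounds share one core and differ only in one group on the attached aromatic ring. Compound 1 `CCCN(CCC)c1cc(C)nc2c(-c3ncc([N+](=O)[O-])cc3C)c(C)nn12` gives 9.1 nM in an assay on isolated protein for binding affinity to corticotropin-releasing factor receptor 1 (Homo sapiens); on this read-out higher numbers stand for weaker inhibition and lower numbers for stronger inhibition. Compound 2 `CCCN(CCC)c1cc(C)nc2c(-c3ncc(N(CC)CC)cc3C)c(C)nn12` gives 13 nM in this assay, and compound 3 `CCCN(CCC)c1cc(C)nc2c(-c3ncc(Cl)cc3C)c(C)nn12` gives 6.7 nM. Compound 3 has the lowest of the three numbers, but a 1.4-fold lower number from compound 1 to compound 3 (0.13 log units; within the scatter), a 1.9-fold lower number from compound 2 to compound 3 (0.29 log units; within the scatter) and a 1.4-fold higher number from compound 1 to compound 2 (0.15 log units; within the scatter) all fall within the scatter, so the three cannot be told apart.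

Compound 4 `CCCN(CCC)c1cc(C)nc2c(-c3ncc(C)cc3O)c(C)nn12` has not yet been measured. It differs from compound 3 in that (3-hydroxy-5-methylpyridin-2-yl in place of 5-chloro-3-methylpyridin-2-yl on an aromatic carbon). Among the compounds with values here, none of the measured steps tests this exact change: each exchanged one group while the methyl stayed where it was, whereas here the methyl moves and a hydroxy appears. Going by these compounds, those steps show that three different groups were tolerated without a shift beyond the scatter, which argues against a large change, but the new pairing is untested, so a modest weakening is allowed for. Compound 4 is therefore expected to give about 20 nM in this assay, with a range from 6 nM to 80 nM, meaning an expected step of a 3.0-fold higher number from compound 3 to compound 4 (0.47 log units; beyond the scatter).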

Compound 4, inhibition constant: > 10000 nM
Compound 4 gave a limit, no number; the forecaster's own chance of this, stated with the estimate: 5%; middle value at least 500-fold (2.69 log units) away from the limit.
By their numbers in this assay, from the lowest: compounds 3, 1 and 2 (each within the scatter of the next). At a limit, above all of these: compound 4.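

In this assay, compound 4 gives a limit and not a number: the limit of > 10000 nM in this assay, at which 1 of the 4 values shown sits.

Putting 3-hydroxy-5-methylpyridin-2-yl in place of 5-chloro-3-methylpyridin-2-yl brings an at least 1400-fold higher number from compound 3 to compound 4 (3.17 log units; beyond the scatter). The earlier compounds shown here made this aromatic ring look forgiving, since nitro, diethylamino and chloro could not be told apart, but that tolerance clearly does not extend to every change on the ring.

This one swap moves the methyl and brings in a hydroxy together, so the compounds shown cannot say which of the two matters, or whether only the pairing does. The open question could be addressed by a ring that keeps the methyl as in compound 3 and carries a hydroxy, a methoxy or an amine in place of the chloro.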